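A few compounds are considered here, and "the series" means these few. Any claim that something is new, unique, unknown or untested is made for them only; others in the source may bear on it.

Measured values in a functional assay for inhibition, with Homo sapiens as the target; a lower number here means a stronger inhibitor, a higher number a weaker inhibitor:
- compound 1 `Cc1nnc(S)n2cncc12`: > 48000 nM, a limit of the assay
- compound 2 `Sc1nncc2cncn12`: > 48000 nM, a limit of the assay
- compound 3 `C=CCSc1nncc2c(C)nc(C)n12`: 59000 nM

Compound 1 stands only at a limit in this assay. Compound 2 likewise stands only at a limit. Compound 3 gives a number, and a weak one. For the measured compounds named here, the one step measured from compound 1, a step that the two limits leave unreadable from compound 1 to compound 2, cannot be read because of the limit of > 48000 nM in this assay, at which 2 of the 3 values shown sit.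

Compound 4 `CCCc1ncc2c(C)nnc(S)n12` differs from compound 1 by propyl in place of hydrogen on an aromatic carbon. Going by the values given here, no measured step puts a propyl at this place, and the only step from compound 1 is unreadable, so nothing measured bears on the change. Compound 4 is therefore expected to stay weak, with a step that the limit leaves unreadable from compound 1 to compound 4 expected to be no step beyond the scatter. The estimate for compound 4 is 60000 nM, in the range 20000 nM to 200000 nM.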

Compound 4, half-maximal inhibitory concentration: > 48000 nM
Compound 4: no number, only a limit (the forecaster's own chance of this, stated with the estimate: 65%); the middle value does not contradict the limit.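

The step from compound 1 to compound 4 cannot be read because both compounds stand only at a limit: the limit of > 48000 nM in this assay, at which 3 of the 4 values shown sit. The compounds shown leave open whether propyl in place of hydrogen on an aromatic carbon changes inhibition at all.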